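The compounds below may be only part of what the source reports. "The series", "measured", "known", "first", "only" and "open" are said of these compounds alone.

Compounds measured so far:
Compound 1, `C=Cc1ccc(S(=O)(=O)Nc2ccc3oc(-c4ccccc4)nc3c2)cc1`, in an assay on cells for inhibition of HSP60/HSP10 (Homo sapiens), with a stated time of 60 min; a higher number here means a weaker inhibitor, a lower number a stronger inhibitor: compound 1 gives > 100000 nM, which is a limit of the assay rather than a number.
Compound 2, `O=S(=O)(Nc1ccc2oc(-c3ccccc3)nc2c1)c1ccccc1F`: compound 2 gives > 100000 nM, again only a limit.
Compound 3, `O=S(=O)(Nc1ccc2oc(-c3ccccc3)nc2c1)c1cccc(Cl)c1`: compound 3 gives > 100000 nM, again only a limit.

Compound 3 therefore stands nowhere definite on the numbers shown: its value is a limit, and the two other values shown are limits too, so that all three measurements sit at the same place, (the limit of > 100000 nM in this assay, at which 3 of the 3 values shown sit). The steps between them cannot be read: a step that the two limits leave unreadable from compound 1 to compound 2, a step that the two limits leave unreadable from compound 1 to compound 3 and a step that the two limits leave unreadable from compound 2 to compound 3 are all steps whose size the two limits hide. The shared core is the same in all three; only the ring on the sulfonyl sulfur changes.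

The next change is of the same kind: 2-methoxyphenyl in place of 3-chlorophenyl on a sulfonyl sulfur, giving compound 4, `COc1ccccc1S(=O)(=O)Nc1ccc2oc(-c3ccccc3)nc2c1`. Within the data shown here, no measured step bears readably on this change, and the three rings tried so far all left the value at the limit. It is therefore expected that the step that the limit leaves unreadable from compound 3 to compound 4 stays unreadable, and compound 4 is estimated at 150000 nM, within 40000 nM to 600000 nM, most likely reported only as a limit once more.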

Compound 4, half-maximal inhibitory concentration: > 100000 nM
Compound 4 gave a limit, no number; the forecaster's own chance of this, stated with the estimate: 85%; the middle value lies beyond the limit too.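

In this assay compound 4 gives > 100000 nM, which is a limit and not a number. No step from compound 1, compound 2 or compound 3 to compound 4 can be read, and all four compounds sit at the same place: the limit of > 100000 nM in this assay, at which 4 of the 4 values shown sit.

Open, from the compounds shown here alone, is how these rings on the sulfonyl sulfur truly compare, and whether any ring there gives a measurable value on the shared core.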